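A few compounds are considered here, and "the series" means these few. Any claim that something is new, unique, unknown or untested is made for them only; others in the source may bear on it.

Three compounds that share one core, differing only in the group carried on an aromatic nitrogen of that core, have been tested in a functional assay on MDA-MB-468 cells (Homo sapiens) for antiproliferative activity, read by MTT assay, with a stated time of 72 h; on this read-out higher numbers stand for weaker inhibition and lower numbers for stronger inhibition. Compound 1 `CCn1ccnc1-c1cc(OC)c(OC)c(OC)c1` carries an ethyl on that nitrogen. In this assay compound 1 gives only a limit, > 100000 nM, so no number is known for it (the limit of > 100000 nM in this assay, at which 1 of the 3 values shown sits). Compound 2 `COc1cc(-c2nccn2-c2ccc3[nH]ccc3c2)cc(OC)c1OC` carries a much larger group on the same nitrogen, and in this assay compound 2 gives 2300 nM. Compound 3 `COc1cc(OC)cc(-n2ccnc2-c2cc(OC)c(OC)c(OC)c2)c1` also carries a larger group there, and in this assay compound 3 gives 57500 nM. For the measured compounds named here, compound 2 and compound 3 each differ from compound 1 in more than one counted place, so no single step between any pair of them is given; their values only show that both sit inside the range the assay can count, while compound 1 stands at the edge of it with a limit alone.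

The next compound, compound 4 `COc1cc(-c2nccn2-c2ccc(F)cc2)cc(OC)c1OC`, differs from compound 1 in one place: 4-fluorophenyl in place of ethyl on an aromatic nitrogen. On the numbers shown, a step from compound 1 to compound 4 toward stronger inhibition, well beyond the usual scatter, is expected, an at least 8.3-fold lower number from compound 1 to compound 4 (0.92 log units; beyond the scatter). Compound 4 is expected to give 12000 nM in this assay, estimated between 2500 nM and 60000 nM.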

Compound 4, half-maximal inhibitory concentration: 62200 nM
Estimate against measurement, compound 4: 5.2-fold (0.71 log units) below; measured number outside the range, above it.
By their numbers in this assay, from the lowest: compound 2; then compounds 3 and 4 (each within the scatter of the next). At a limit, above all of these: compound 1.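

For the compounds shown here, compound 4 gives this position its first single-change comparison, as the earlier compounds each differed from compound 1 in more than one counted place: in this assay, 4-fluorophenyl in place of ethyl on the aromatic nitrogen gives an at least 1.6-fold lower number from compound 1 to compound 4 (0.20 log units; that floor lies within the scatter). A measured number now stands for a compound with this six-membered aromatic ring on that nitrogen, but the printed floor of the step lies within the usual scatter, so this pair alone does not establish a real gain in inhibition. The true size of the step remains unknown, because compound 1 has only a limit and not a number: the limit of > 100000 nM in this assay, at which 1 of the 4 values shown sits.

The compounds shown leave open how a plain phenyl group, without the fluorine, would compare with 4-fluorophenyl, so the share of the ring and the share of the fluorine in this step cannot be separated. Also open, on these data alone, is what a longer chain such as hexyl, an aminoethyl chain or a chain ending in a carboxylic acid would give on the same nitrogen.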